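The compounds below may be only part of what the source reports. "The series", "measured", "known", "first", "only" and "open" are said of these compounds alone.

Measured so far in an ADME assay on MDCK cells (Canis lupus familiaris) for cytotoxicity, read by microscopy, with a stated time of 48 h; a higher number here means that more compound is tolerated, a lower number that less compound is tolerated:
- compound 1, `C[C@H]1[C@H](NCc2cnccn2)C[C@H]2C[C@@H]1C2(C)C`: > 100000 nM
- compound 2, `C[C@H]1[C@H](NCc2ccc(Cl)s2)C[C@H]2C[C@@H]1C2(C)C`: 25000 nM
- compound 3, `C[C@H]1[C@H](NCc2sccc2Br)C[C@H]2C[C@@H]1C2(C)C`: 50000 nM

The value of compound 1 in this assay is a limit of the assay, not a number (the limit of > 100000 nM in this assay, at which 1 of the 3 values shown sits). Among the two numbers actually reported, compound 3 gives the highest; its nearest neighbour is compound 2, and the two lie within the scatter of each other, so no order between them is claimed.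

Compound 4, `C[C@H]1[C@H](NCc2nccs2)C[C@H]2C[C@@H]1C2(C)C`, is not yet measured in this assay. It differs from compound 3 as follows: 1,3-thiazol-2-yl in place of 3-bromothiophen-2-yl on a saturated chain carbon bound to an amine nitrogen

Among the compounds with values here, the steps that bear on this change are those that swap the aromatic ring on the saturated chain carbon bound to the amine nitrogen. The step of an at least 2.0-fold lower number from compound 1 to compound 3 (0.30 log units; that floor lies within the scatter) and the step of an at least 4.0-fold lower number from compound 1 to compound 2 (0.60 log units; beyond the scatter) both run from the ring with two hetero atoms toward a halogenated thiophene and lower the number; the step of a 2.0-fold higher number from compound 2 to compound 3 (0.30 log units; within the scatter) stays within the scatter. The change from compound 3 to compound 4 moves back toward a ring with two hetero atoms, so a modest upward step in this assay is expected, though the limit on compound 1 leaves its size open.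

Compound 4 is therefore expected to give about 100000 nM in this assay, within 40000 nM to 200000 nM, which amounts to an estimated step of a 2.0-fold higher number from compound 3 to compound 4 (0.30 log units; within the scatter).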

Compound 4, minimum cytotoxic concentration: > 100000 nM
Compound 4 gave a limit, no number; the forecaster's own chance of this, stated with the estimate: 45%; the middle value sits exactly at the limit.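

In this assay compound 4 gives a limit of the assay, not a number, and it joins compound 1 there: the limit of > 100000 nM in this assay, at which 2 of the 4 values shown sit. Within the data shown here, the swap of ring gives an at least 4.0-fold higher number from compound 2 to compound 4 (0.60 log units; beyond the scatter) and an at least 2.0-fold higher number from compound 3 to compound 4 (0.30 log units; that floor lies within the scatter), so only the step away from 5-chlorothiophen-2-yl is certain to lie beyond the scatter, while the floor of the step away from 3-bromothiophen-2-yl stays within it. Pyrazin-2-yl is thus no longer the only ring at this place to reach the limit: a five-membered aromatic ring with 2 hetero atoms does so too, both halogenated thiophenes of this set give numbers, and no compound of the four goes against this split, though the step from compound 1 to compound 4 cannot be read, which leaves the two rings unordered.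

An unsubstituted thiophen-2-yl group would show whether the halogen or the added ring nitrogen goes with the split, and the compounds shown do not settle that. Going by these compounds, also open in this assay is how a phenyl group, or a longer chain on the amine nitrogen, would stand.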